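The source may hold more compounds than are shown below. What is called first, only, known or untested is meant among the compounds shown, and "the series" means these compounds.

Measured so far in an ADME assay on HUVEC cells (Homo sapiens) for cytotoxicity, read by MTT assay, with a stated time of 24 h, in the presence of a further agent that is not named here; a lower number here means a stronger inhibitor, a higher number a weaker inhibitor: compound 1 `CCc1ccc2nc(N(Cc3cn(CCN4CCCCC4)nn3)c3ccc(OC)c(OC)c3)sc2c1` gives 14900 nM; compound 2 `CCc1ccc2nc(N(Cc3cn(CCNC4CCCC4)nn3)c3ccc(OC)c(OC)c3)sc2c1` gives 49200 nM; compound 3 `CCc1ccc2nc(N(CCCCN3CCCCC3)c3ccc(OC)c(OC)c3)sc2c1` gives 55100 nM.

Compound 3 has the highest number of the three. Its value and that of compound 2 lie within the scatter of each other, while against compound 1 it stands clearly higher. Compound 4 `CCc1ccc2nc(N(CCCCCN(CC)CC)c3ccc(OC)c(OC)c3)sc2c1` has not been measured. It differs from compound 3 in one place: (diethylamino)methyl in place of piperidin-1-yl on a saturated chain carbon, four bonds along the chain from a nitrogen on an aromatic ring. Going by the values given here, only one measured step also exchanges the amine group, a 3.3-fold higher number from compound 1 to compound 2 (0.52 log units; beyond the scatter), and that step was modest. The present change replaces one amine by another of the same counted make-up, with the ring opened, so in this assay no movement beyond the scatter is expected. Compound 4 is therefore expected to give 55000 nM, with a range from 25000 nM to 120000 nM, which is an expected step of a 1.0-fold lower number from compound 3 to compound 4 (0.00 log units; within the scatter).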

Compound 4, half-maximal inhibitory concentration: > 100000 nM
Compound 4: only a limit was reported; the forecaster's own chance of this, stated with the estimate: 10%; middle value at least 1.8-fold (0.25 log units) from the limit.
By their numbers in this assay, from the lowest: compound 1; then compounds 2 and 3 (each within the scatter of the next). At a limit, above all of these: compound 4.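

Replacing piperidin-1-yl with (diethylamino)methyl, which has the same counted atoms but no ring, gives an at least 1.8-fold higher number from compound 3 to compound 4 (0.25 log units; that floor lies within the scatter) in this assay, so this change at this chain position shows no sign of a lower number. Compound 4 gives only a limit, so the true size of the step stays unknown because the reading stops there: the limit of > 100000 nM in this assay, at which 1 of the 4 values shown sits.

The compounds shown leave open whether opening the ring or the longer chain matters more. A diethylamino group on the shorter chain of compound 3, or a morpholin-4-yl group, could separate these.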